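This account rests on a few compounds, and the source may have more. Where it says the series, first, only, none or still open, it means among the compounds named here.

Measured so far:
compound 1 `O=C(NCc1nn2c(Cc3ccccc3)nnc2s1)c1ccccc1` — 28%
compound 2 `c1ccc(OCc2nnc3sc(Cc4cccc5ccccc45)nn23)cc1` — 24.6%

In a functional assay on the whole organism (strain Wistar) for inhibition, with Rattus norvegicus as the target, read by paw edema, with stated times of 30 min and 3 h, at a dose of 20 mg/kg by the oral route (on this read-out lower numbers stand for less inhibition and higher numbers for more inhibition at the one dose given (going by the name of the read-out)), compound 1 gives 28% and compound 2 gives 24.6%; the gap between them lies within the scatter, so neither can be set apart from the other on these two numbers. Compound 3 `O=C(NCc1nn2c(-c3ccccc3O)nnc2s1)c1ccccc1` is not yet measured. It differs from compound 1 in one place: 2-hydroxyphenyl in place of benzyl on an aromatic carbon. Among the compounds with values here, no measured pair shows what this change does in this assay. The step is expected to be small, a number 2 percentage points higher from compound 1 to compound 3 (within the scatter), with no direction claimed beyond the scatter. Compound 3 is therefore expected to give about 30%, within 15% to 45%, because compound 1 gives 28%.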

Compound 3, a percentage reported as inhibition, in the whole organism at one dose (the size of the read-out at that dose, not a potency): 32.3%
Compound 3: middle estimate off by 2.3 percentage points, on the low side, and the stated range covers the measured number.
By their numbers in this assay, from the lowest: compounds 2, 1 and 3 (each within the scatter of the next).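

In this assay, 2-hydroxyphenyl in place of benzyl gives a number 4.3 percentage points higher from compound 1 to compound 3 (within the scatter), so at this single dose compound 3 cannot be set apart from compound 1. This position therefore takes either group without a difference that stands clear of the scatter, even though only 2-hydroxyphenyl brings a hydrogen-bond donor. No measurement is available that bears on why. The compounds shown leave open what plain phenyl, with no hydroxyl, would give here, and whether an amine or a longer chain at this position would give a number beyond the scatter.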